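Swapping a pyrazole for trifluoromethylsulfanyl: the solubility outlook

This account rests on a few compounds, and the source may have more. Where it says the series, first, only, none or still open, it means among the compounds named here.

Of the compounds shown here, three have so far been measured in a physicochemical assay for solubility, using the shake flask method, in simulated intestinal fluid, measured as kinetic solubility, with a stated time of 2 h, at 25 degrees C, at pH 6.5; on this read-out higher numbers stand for higher solubility and lower numbers for lower solubility. Compound 1 `Cc1nc(C#N)c(N)c2c1C(=O)N(Cc1ccccc1)C2=O` gives < 5000 nM, which is a limit of the assay rather than a number. Compound 2 `CCCOC(=O)c1nc(C)c2c(c1N)C(=O)N(Cc1ccccc1)C2=O` gives < 5000 nM, also a limit. Within the data shown here, the only step between two measured compounds, a step that the two limits leave unreadable from compound 1 to compound 2, therefore cannot be read. Compound 3 `Cc1noc(-c2nc(C)c3c(c2N)C(=O)N(Cc2ccc(-n4cccn4)cc2)C3=O)n1` gives < 5000 nM, again a limit. All three values sit at the limit of < 5000 nM in this assay, at which 3 of the 3 values shown sit.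

Compound 4 `Cc1noc(-c2nc(C)c3c(c2N)C(=O)N(Cc2ccc(SC(F)(F)F)cc2)C3=O)n1` differs from compound 3 by (trifluoromethyl)sulfanyl in place of 1H-pyrazol-1-yl on an aromatic carbon. Among the measured compounds shown here, no measured step bears on this change, and no measured step has a readable size. The step that the limit leaves unreadable from compound 3 to compound 4 is therefore estimated to stay within the scatter. Compound 4 is expected to give 2000 nM, somewhere between 400 nM and 8000 nM.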

Compound 4, solubility: < 5000 nM
Compound 4: no number, only a limit; the forecaster's own chance of this, stated with the estimate: 80%; the middle value does not contradict the limit.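

In this assay compound 4 gives < 5000 nM which is a limit, so no step from compound 3 to compound 4, or between any compounds shown, can be read: the limit of < 5000 nM in this assay, at which 4 of the 4 values shown sit. As far as these compounds go, how far each of the four compounds lies from that limit stays open.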